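The source may report more compounds than this note shows. Statements on the series, on what has been measured and on what is new or still open speak of the compounds shown alone.

Compound 1 `O=C(CCc1cccc2c1B(O)OC2)Nc1ccc(F)cc1`, compound 2 `O=C(CCc1cccc2c1B(O)OC2)Nc1ccc(Cl)cc1`, compound 3 `O=C(CCc1cccc2c1B(O)OC2)Nc1ccc(Br)cc1`, and the unmeasured compound 4 `O=C(CCc1cccc2c1B(O)OC2)Nc1ccc([N+](=O)[O-])cc1` share one core and differ only in the group on the outer aromatic ring.

In a functional assay on MDA-MB-231 cells (Homo sapiens) for antiproliferative activity, read by MTT assay, with a stated time of 72 h (a lower number here means a stronger inhibitor, a higher number a weaker inhibitor), compound 1 gives 440 nM, compound 2 gives 3600 nM, and compound 3 gives 5300 nM. Compound 2 stands second highest of the three numbers: compound 3 is nearest, with a 1.5-fold higher number from compound 2 to compound 3 (0.17 log units; within the scatter), and compound 1 is furthest, with an 8.2-fold higher number from compound 1 to compound 2 (0.91 log units; beyond the scatter).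

Compound 4 differs from compound 2 by nitro in place of chloro on an aromatic carbon. Every measured step swaps one halogen for another, with a 12-fold higher number from compound 1 to compound 3 (1.08 log units; beyond the scatter) as the largest; none introduces a nitro group, so direction cannot be read from them, and a step of a 1.2-fold lower number from compound 2 to compound 4 (0.08 log units; within the scatter) is expected only as a rough guess. Compound 4 is expected to give 3000 nM, between 700 nM and 13000 nM.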

Compound 4, half-maximal inhibitory concentration: 36000 nM
Compound 4: the middle estimate sits 12-fold (1.08 log units) below what was measured; measured number above the stated range.
By their numbers in this assay, from the lowest: compound 1; then compounds 2 and 3 (each within the scatter of the next); then compound 4.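

At this position, nitro is the only group shown that is not a halogen, and in this assay it brings a 10-fold higher number from compound 2 to compound 4 (1.00 log units; beyond the scatter) and a 6.8-fold higher number from compound 3 to compound 4 (0.83 log units; beyond the scatter) as well as an 82-fold higher number from compound 1 to compound 4 (1.91 log units; beyond the scatter) as the widest step in the series. With all three steps beyond the scatter, compound 4 is the weakest of the four, so a change here can cost more than swapping chloro for bromo does. Nothing shown explains this loss. On these data alone, how an amine, a methoxy group or a carboxylic acid at this position would compare remains open, as does whether any group can give a lower number than compound 1 does.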